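The source may report more compounds than this note shows. Statements on the series, on what has been measured and on what is new or still open speak of the compounds shown alone.

Measured so far:
Compound 1 `O=[N+]([O-])c1ccc(-n2cc(-c3ccc(C(F)(F)F)cc3)cn2)cc1` — in a functional assay on HL-60 cells (Homo sapiens) for cytotoxicity, read by MTT assay, with a stated time of 48 h (on this read-out lower numbers stand for stronger inhibition and higher numbers for weaker inhibition), compound 1 gives 17300 nM.
Compound 2 `O=[N+]([O-])c1ccc(-n2cc(-c3cc(C(F)(F)F)cc(C(F)(F)F)c3)cn2)cc1` — in this assay compound 2 gives 11400 nM.

Of these two numbers, compound 1 holds the higher one, yet its gap to compound 2 lies within the usual scatter of repeated measurements, so the two cannot be told apart on this read-out. Compound 3 `O=[N+]([O-])c1ccc(-c2cnn(-c3ccc([N+](=O)[O-])cc3)c2)cc1` has not yet been measured. It differs from compound 1 in one place: nitro in place of trifluoromethyl on an aromatic carbon. Within the data shown here, no measured pair isolates this change, so there is no measured step to lean on. Among the measured compounds shown here, both compounds measured so far carry a trifluoromethyl group on that ring and sit close to each other in this assay, which gives no sign that changes at this position move the number far. The step from compound 1 to compound 3, a 1.2-fold lower number from compound 1 to compound 3 (0.06 log units; within the scatter), is therefore expected to stay within the scatter, in either direction. Compound 3 is estimated at 15000 nM, with a likely range from 5000 nM to 45000 nM.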

Compound 3, half-maximal inhibitory concentration: 8780 nM
The estimate for compound 3 lay 1.7-fold (0.23 log units) above the measured number, within the range that was stated.
By their numbers in this assay, from the lowest: compounds 3, 2 and 1 (each within the scatter of the next).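

In this assay, among these compounds, putting nitro in place of trifluoromethyl on this aromatic carbon gives a 2.0-fold lower number from compound 1 to compound 3 (0.29 log units; within the scatter), the first measured step for a single change at this position. This step does not separate the two groups on this read-out, even though nitro brings hydrogen-bond acceptors and a double bond that trifluoromethyl lacks, so for this pair those differences come with no clear shift in the number. Nothing measured here bears on this result or offers an explanation for it.

From the compounds shown here alone, one swap between two groups cannot show how much this position tolerates, so it remains open whether a very different group would move the number beyond the scatter. An amine, a carboxylic acid or a longer chain on this carbon could test that, and any of them might give a clearly lower or higher number.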